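Alkoxymethyl Chain Length at the Double-Bonded Ring Carbon

This account rests on a few compounds, and the source may have more. Where it says the series, first, only, none or still open, it means among the compounds named here.

Measured in a functional assay on the whole organism for inhibition, with Mus musculus as the target, at a dose of 10 mg/kg; a lower number here means less inhibition, a higher number more inhibition at the dose given (going by the name of the read-out):
compound 1 `O=C1C=CS(=O)(=O)c2ccccc21`: 5.5%
compound 2 `COCC1=CS(=O)(=O)c2ccccc2C1=O`: 99.9%
compound 3 `CCOCC1=CS(=O)(=O)c2ccccc2C1=O`: 92.4%

Compound 3 stands second highest of the three numbers, separated from its nearest neighbour by a number 7.5 percentage points lower from compound 2 to compound 3 (within the scatter) and from the furthest by a number 86.9 percentage points higher from compound 1 to compound 3 (beyond the scatter).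

Compound 4 `CCCOCC1=CS(=O)(=O)c2ccccc2C1=O` differs from compound 3 by methyl in place of hydrogen on a saturated chain carbon, two bonds along the chain from an oxygen on a saturated carbon. Among the measured compounds shown here, two steps bear on this. The large gains of a number 94.4 percentage points higher from compound 1 to compound 2 (beyond the scatter) and a number 86.9 percentage points higher from compound 1 to compound 3 (beyond the scatter) come from putting the alkoxymethyl group on the ring at all. The closer precedent, lengthening the chain by one carbon, gave a number 7.5 percentage points lower from compound 2 to compound 3 (within the scatter), within the scatter. A further carbon is therefore expected to move the number by no more than the scatter, if at all, in this assay.

Compound 4 is expected to give 88%, between 70% and 99.9%, in this assay. That estimate means a step of a number 4.4 percentage points lower from compound 3 to compound 4 (within the scatter), expected within the scatter.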

Compound 4, a percentage reported as inhibition, in the whole organism at one dose (the size of the read-out at that dose, not a potency): 99.9%
Beside the measured number, compound 4's estimate is 11.9 percentage points below it; the range from low to high includes it.
By their numbers in this assay, from the lowest: compound 1; then compounds 3, 2 and 4 (each within the scatter of the next).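

In this assay, the gain at the double-bonded ring carbon extends to propoxymethyl, with a number 94.4 percentage points higher from compound 1 to compound 4 (beyond the scatter). Going from ethoxy to propoxy gives a number 7.5 percentage points higher from compound 3 to compound 4 (within the scatter), and ethyl in place of hydrogen on the methoxymethyl chain gives no change at the digits printed from compound 2 to compound 4 (within the scatter), so methoxymethyl, ethoxymethyl and propoxymethyl cannot be told apart here. No evidence bears on this result.

From the compounds shown here alone, whether a longer chain such as butoxymethyl, or an aminomethyl group, at the double-bonded ring carbon keeps this level remains open. A single-dose read-out also leaves relative potency within the series unresolved.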